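The source may report more compounds than this note shows. Statements on the series, on what has been measured and on what is new or still open speak of the compounds shown alone.

Compound 1, `Oc1nc2nonc2nc1Nc1ccc(OCC(F)(F)F)cc1`, gives 42300 nM in an assay on mitochondria from L6 cells (Rattus norvegicus) for activation, with a stated time of 90 min; on this read-out higher numbers stand for an effect only at larger amounts of compound and lower numbers for an effect already at smaller amounts.
Compound 2, `Cc1cc(Nc2nc3nonc3nc2O)ccc1OCC(F)(F)F`, gives 7000 nM in this assay.
Compound 3, `Cc1ccc(C(F)(F)F)cc1Nc1nc2nonc2nc1O`, gives 32800 nM in this assay.

All three share the same core and differ only in the aromatic ring attached to it. Between compound 2 and compound 1 a single change is made, (hydrogen in place of methyl on an aromatic carbon), and it brings a 6.0-fold higher number from compound 2 to compound 1 (0.78 log units; beyond the scatter). How compound 3 differs from compound 2 is not broken down here, since the two differ in more than one place. The values of compound 3 and compound 1 lie within the usual scatter of each other, so nothing can be said about an order between them.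

Compound 4, `Oc1nc2nonc2nc1Nc1cccc(C(F)(F)F)c1`, has not been measured in this assay. It differs from compound 3 by hydrogen in place of methyl on an aromatic carbon. Within the data shown here, this is the same kind of change as the one from compound 2 to compound 1, but the surroundings differ: there the hydrogen entered ortho to a 2,2,2-trifluoroethoxy group and meta to a large group, here it enters ortho to a large group and para to a trifluoromethyl group. Among the measured compounds shown here, only one earlier example of this change is available, so the expectation rests on it alone. Because compound 2 to compound 1 showed a 6.0-fold higher number from compound 2 to compound 1 (0.78 log units; beyond the scatter), a step of a 3.4-fold higher number from compound 3 to compound 4 (0.53 log units; beyond the scatter) is expected from compound 3 to compound 4, with wide uncertainty. Compound 4 is therefore estimated at 110000 nM in this assay, with a likely range from 30000 nM to 400000 nM.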

Compound 4, half-maximal effective concentration: 13300 nM
Beside the measured number, compound 4's estimate is 8.3-fold (0.92 log units) above it; the whole stated range lies above it.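

In this assay, putting hydrogen in place of the methyl group brings a 2.5-fold lower number from compound 3 to compound 4 (0.39 log units; beyond the scatter), so removing this methyl does not raise the number here as it did in the earlier example. Set side by side, the two examples do not agree even in direction: the same change on two cores in this assay, a 6.0-fold higher number (0.78 log units; beyond the scatter) from compound 2 to compound 1 and a 2.5-fold lower number (0.39 log units; beyond the scatter) from compound 3 to compound 4, 15-fold (1.17 log units) apart, beyond the scatter of two such steps. This shows that, within this series, a step seen for this change on one core cannot simply be carried over to another, and that the rest of the molecule matters to the outcome; it does not show which feature of the surroundings is responsible, as the two pairs differ both in the other group on the ring, 2,2,2-trifluoroethoxy or trifluoromethyl, and in where the change takes place, and two pairs are too few to give a rule.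

The compounds shown leave open how a chlorine atom, an ethyl group or a methoxy group on the same aromatic carbon would compare with methyl and hydrogen on each core. They also leave open whether further pairs carrying this change, for example with an amine or a carboxylic acid elsewhere on the ring, would follow the first example, the second or neither.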